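Removing a methyl from compound 2: what toxicity to expect

The compounds below may be only part of what the source reports. "The series", "measured", "known", "first", "only" and "open" are said of these compounds alone.

Compound 1 `O=C(Nc1cccc(-n2cc(-c3ccncc3)c(-c3ccc(Cl)c(O)c3)n2)c1)Nc1cccc(C(F)(F)F)c1` and compound 2 `COc1cc(-c2nn(-c3cccc(NC(=O)Nc4ccc(Cl)c(Cl)c4)c3)cc2-c2ccncc2)ccc1Cl` share one core, and both were tested in a functional assay on RPMI-8226 cells (Homo sapiens) for inhibition, read by sulforhodamine B assay, with a stated time of 48 h; on this read-out higher numbers stand for lower toxicity in this test and lower numbers for higher toxicity in this test. Compound 1 gives only a limit in this assay, > 32500 nM. Compound 2 likewise gives only a limit in this assay, > 50000 nM. Compound 2 therefore stands at one of the two limits shown, (the limit of > 50000 nM in this assay, at which 1 of the 2 values shown sits). Compound 1 stands at the other, (the limit of > 32500 nM in this assay, at which 1 of the 2 values shown sits). Going by the values given here, neither value is a number, and no step between measured compounds can be read from them. Compound 3 `O=C(Nc1cccc(-n2cc(-c3ccncc3)c(-c3ccc(Cl)c(O)c3)n2)c1)Nc1ccc(Cl)c(Cl)c1` has not yet been measured. It differs from compound 2 in one place: hydrogen in place of methyl on an oxygen on an aromatic ring. Among the compounds with values here, no measured pair shows this change alone, so no step beyond the scatter is expected in either direction. Compound 3 is expected to give 50000 nM in this assay, between 20000 nM and 100000 nM, most probably again as a limit. For compound 3 the expected step is a number no higher from compound 2 to compound 3 (the limit leaves the size open).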

Compound 3, concentration lethal to 50% of the cells: > 32500 nM
Compound 3: no number, only a limit; the forecaster's own chance of this, stated with the estimate: 80%; the middle value lies beyond the limit too.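

In this assay compound 3 gives only a limit, > 32500 nM, so no step can be read between it and compound 1 or compound 2, whose results are also limits. The compounds shown leave open whether going from methoxy to hydroxy, or from 3-(trifluoromethyl)phenyl to 3,4-dichlorophenyl, changes the result in this assay at all.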